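The source may report more compounds than this note shows. Statements on the series, on what has been measured and on what is new or still open speak of the compounds shown alone.

Measured so far:
- compound 1 `O=S(=O)(Nc1ccc2oc(-c3ccccc3)nc2c1)c1cccc(C(F)(F)F)c1` — > 100000 nM in an assay on cells for inhibition of HSP60/HSP10 (Homo sapiens), with a stated time of 60 min; a lower number here means a stronger inhibitor, a higher number a weaker inhibitor
- compound 2 `O=S(=O)(Nc1ccc2oc(-c3ccccc3)nc2c1)c1ccccc1O` — 85000 nM
- compound 3 `O=S(=O)(Nc1ccc2oc(-c3ccccc3)nc2c1)c1ccc(Cl)c(Cl)c1` — > 100000 nM

In this assay the values of compound 1 and compound 3 are limits of the assay rather than numbers; the limit is the one of the limit of > 100000 nM in this assay, at which 2 of the 3 values shown sit. Going by the values given here, compound 2 is the only one with a number, and it is a high one. Compound 3 therefore stands at the edge of what this assay can report, on the weak side. Among the compounds with values here, the step from compound 2 to compound 3, an at least 1.1-fold higher number from compound 2 to compound 3 (0.07 log units; that floor lies within the scatter), is the only measured step that bears on the change now in view, and its floor lies within the scatter.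

Compound 4 `Cc1cccc(S(=O)(=O)Nc2ccc3oc(-c4ccccc4)nc3c2)c1` differs from compound 3 by 3-methylphenyl in place of 3,4-dichlorophenyl on a sulfonyl sulfur. The evidence is thin: one step whose size cannot be pinned down, and two limits. Nothing in the three measured compounds suggests that swapping one small aryl group for another on the sulfonyl sulfur moves the number far. Compound 4 is therefore expected to remain weak, with an estimated value of 100000 nM (between 40000 nM and 300000 nM), meaning an expected step of a number no higher from compound 3 to compound 4 (the limit leaves the size open).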

Compound 4, half-maximal inhibitory concentration: > 100000 nM
Compound 4: no number, only a limit; the forecaster's own chance of this, stated with the estimate: 60%; the middle value sits exactly at the limit.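

Going by these compounds alone, compound 4 gives only a limit, which shows that 3-methylphenyl, a group of carbon only, also yields no number on the sulfonyl sulfur, as did the chlorine-bearing group of compound 3 and the fluorine-bearing group of compound 1, so the weak end of the assay now holds most of the set: the limit of > 100000 nM in this assay, at which 3 of the 4 values shown sit. The one readable step is an at least 1.1-fold higher number from compound 2 to compound 4 (0.07 log units; that floor lies within the scatter), so 3-methylphenyl cannot be told apart from 2-hydroxyphenyl on this evidence. The steps to compound 4 from compound 1 and from compound 3 cannot be read, with limits at both ends.

Going by these compounds, how far compound 1, compound 3 and compound 4 lie past the limit stays open, so they cannot be ranked. Also open, on these data alone, is whether an amine or a carboxylic acid on this aryl ring would give a stronger number than compound 2 with its 85000 nM.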